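Notes on the aryl swap from compound 1 to compound 4

This account rests on a few compounds, and the source may have more. Where it says the series, first, only, none or still open, it means among the compounds named here.

Compound 1 `COc1cc(/C=C2\CCC/C(=C\c3ccc(F)c(F)c3)C2=O)cc(OC)c1OC` sits as the highest of the two numbers in a functional assay on SW-620 cells (Homo sapiens) for antiproliferative activity, read by MTT assay, with a stated time of 72 h (a lower number here means a stronger inhibitor, a higher number a weaker inhibitor), where compound 1 gives 4100 nM. Compound 2 `COc1cc(/C=C2\CCC/C(=C\c3ccccc3F)C2=O)cc(OC)c1OC` gives 2100 nM in this assay, a difference of a 2.0-fold lower number from compound 1 to compound 2 (0.29 log units; within the scatter). Compound 3 `COc1cc(/C=C2\CCC/C(=C\c3cccc(O)c3)C2=O)cc(OC)c1OC` reaches only the limit > 10000 nM in this assay, so no number is known for compound 3 (the limit of > 10000 nM in this assay, at which 1 of the 3 values shown sits). The step of an at least 2.4-fold higher number from compound 1 to compound 3 (0.38 log units; beyond the scatter) is the only one beyond the scatter. Compound 4 `COc1ccc(/C=C2\CCC/C(=C\c3cc(OC)c(OC)c(OC)c3)C2=O)cc1OC` differs from compound 1 by 3,4-dimethoxyphenyl in place of 3,4-difluorophenyl on a double-bonded chain carbon bound to a double-bonded ring carbon. For the measured compounds named here, no measured step involves a dimethoxyphenyl here; the closest is the hydroxyphenyl step, which weakened. Compound 4 is therefore expected to be somewhat weaker than compound 1, with a 1.5-fold higher number from compound 1 to compound 4 (0.17 log units; within the scatter), estimated at 6000 nM with a range of 2000 nM to 15000 nM.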

Compound 4, half-maximal inhibitory concentration: 1600 nM
Beside the measured number, compound 4's estimate is 3.8-fold (0.57 log units) above it; measured number below the stated range.
By their numbers in this assay, from the lowest: compounds 4, 2 and 1 (each within the scatter of the next, the first and the last beyond it). At a limit, above all of these: compound 3.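

For the compounds shown here, the change to 3,4-dimethoxyphenyl on a double-bonded chain carbon bound to a double-bonded ring carbon is the first move from compound 1 in this assay to lower the number beyond the scatter: a 2.6-fold lower number from compound 1 to compound 4 (0.41 log units; beyond the scatter). Oxygen-bearing aryl groups at this place can therefore differ widely, with an at least 6.2-fold lower number from compound 3 to compound 4 (0.79 log units; beyond the scatter), and compound 3 stands at a limit, not a number: the limit of > 10000 nM in this assay, at which 1 of the 4 values shown sits. Against 2-fluorophenyl, the change gives a 1.3-fold lower number from compound 2 to compound 4 (0.12 log units; within the scatter), which leaves these two groups unseparated.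

Open, going by these compounds, is whether a single methoxy group would account for the step from compound 1. Also open, on these data alone, is how an amine or a carboxylic acid on this aryl ring would compare.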